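The compounds below may be only part of what the source reports. "The series", "measured", "known", "first", "only" and "open" are said of these compounds alone.

Measured compounds:
compound 1 `CC(O)(CSc1cccc(C(F)(F)F)c1)C(=O)Nc1ccc(S(F)(F)(F)(F)F)cc1` with 23400 nM;
compound 2 `CC(O)(CSc1ccccc1C(F)(F)F)C(=O)Nc1ccc(S(F)(F)(F)(F)F)cc1` with 13200 nM;
compound 3 `CC(O)(CS(=O)(=O)c1cccc(C(F)(F)F)c1)C(=O)Nc1ccc(S(F)(F)(F)(F)F)cc1` with 23800 nM.

All three were tested in a functional assay on CWR22R cells (Homo sapiens) for antiproliferative activity, read by propidium iodide staining, with a stated time of 96 h; a lower number here means a stronger inhibitor, a higher number a weaker inhibitor. Compound 1 and compound 2 share a core, and compound 3 carries a different core; the difference between the two cores is not broken down here. Compound 1 and compound 2 differ in one place: 2-(trifluoromethyl)phenyl in place of 3-(trifluoromethyl)phenyl on a sulfur. That change gave a 1.8-fold lower number from compound 1 to compound 2 (0.25 log units; within the scatter). Compound 4 `CC(O)(CS(=O)(=O)c1ccccc1C(F)(F)F)C(=O)Nc1ccc(S(F)(F)(F)(F)F)cc1` has not yet been tested in this assay. It differs from compound 3 in one place: 2-(trifluoromethyl)phenyl in place of 3-(trifluoromethyl)phenyl on a sulfonyl sulfur. The two "place" descriptions are not the same word for word: in the first pair the group sits on a sulfur, in the second on a sulfonyl sulfur, so this is the same kind of change rather than the same change. Within the data shown here, because the earlier change gave a 1.8-fold lower number from compound 1 to compound 2 (0.25 log units; within the scatter), a step of similar, small size is expected from compound 3 to compound 4, a 1.7-fold lower number from compound 3 to compound 4 (0.23 log units; within the scatter), with the single earlier example as its only basis. Compound 4 is therefore estimated at 14000 nM, expected to lie between 6500 nM and 32000 nM.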

Compound 4, half-maximal inhibitory concentration: 17400 nM
Beside the measured number, compound 4's estimate is 1.2-fold (0.09 log units) below it; the measured number falls inside the stated range.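

In this assay, 2-(trifluoromethyl)phenyl in place of 3-(trifluoromethyl)phenyl on a sulfonyl sulfur gave a 1.4-fold lower number from compound 3 to compound 4 (0.14 log units; within the scatter). Set beside the earlier case, the two steps agree: the same change on two cores in this assay, a 1.8-fold lower number (0.25 log units; within the scatter) from compound 1 to compound 2 and a 1.4-fold lower number (0.14 log units; within the scatter) from compound 3 to compound 4, 1.3-fold (0.11 log units) apart, within the scatter of two such steps. This shows that the change behaves alike on these two cores, but each step is small enough to be ordinary scatter, so it does not show that the change really improves activity on either core, and two pairs cannot show that the agreement extends to other cores in the series.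

The compounds shown leave open what a nitrile or a methoxy group in place of trifluoromethyl on the phenyl ring would do to the number. They also leave open whether a sulfoxide in place of the sulfur or sulfonyl link would respond to the same change in the same way.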